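Chain extension on the core: ethyl to propyl

This account rests on a few compounds, and the source may have more. Where it says the series, first, only, none or still open, it means among the compounds named here.

compound 1 `Cn1c(=O)c2[nH]c(Cc3ccco3)nc2n(Cc2ccco2)c1=O`: 316 nM
compound 2 `CCn1c(=O)c2[nH]c(Cc3ccccc3)nc2n(Cc2ccco2)c1=O`: 162 nM
compound 3 `CCn1c(=O)c2[nH]c(Cc3ccco3)nc2n(Cc2ccco2)c1=O`: 126 nM

All three share the core of compound 1 and were measured in an assay on HEK293 cells for displacement of a labelled ligand from adenosine receptor A2b (Homo sapiens); a lower number here means a stronger inhibitor, a higher number a weaker inhibitor. Compound 2 lies between the other two numbers, within the scatter of both: its nearest neighbour is compound 3, and compound 1 is the furthest, each gap within the scatter.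

Compound 4 `CCCn1c(=O)c2[nH]c(Cc3ccccc3)nc2n(Cc2ccco2)c1=O` differs from compound 2 by methyl in place of hydrogen on a saturated chain carbon, two bonds along the chain from an aromatic nitrogen. Going by the values given here, the one measured step of the same kind, one bond closer to the aromatic nitrogen, is a 2.5-fold lower number from compound 1 to compound 3 (0.40 log units; beyond the scatter), a modest gain beyond the scatter. The other step, a 1.3-fold lower number from compound 2 to compound 3 (0.11 log units; within the scatter), concerns a different part of the molecule and does not bear on this change. With a single related step, and that one cut a bond further in, the expectation for this assay is at most a modest lowering, possibly nothing beyond the scatter, and the estimated step is a 1.5-fold lower number from compound 2 to compound 4 (0.17 log units; within the scatter). Compound 4 is therefore estimated at 110 nM, in the range 45 nM to 300 nM.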

Compound 4, inhibition constant: 117 nM
Estimate against measurement, compound 4: 1.1-fold (0.03 log units) below, and the stated range covers the measured number.
By their numbers in this assay, from the lowest: compounds 4, 3, 2 and 1 (each within the scatter of the next, the first and the last beyond it).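

In this assay, lengthening ethyl to propyl, with methyl in place of hydrogen on a saturated chain carbon, two bonds along the chain from an aromatic nitrogen, gives a 1.4-fold lower number from compound 2 to compound 4 (0.14 log units; within the scatter). The position therefore accepts propyl with no loss beyond the scatter, but this step alone does not show a real gain. Read as one change on two cores, the added methyl gives lower numbers both times, and the two steps cannot be told apart: the same change on two cores in this assay, a 2.5-fold lower number (0.40 log units; beyond the scatter) from compound 1 to compound 3 and a 1.4-fold lower number (0.14 log units; within the scatter) from compound 2 to compound 4, 1.8-fold (0.26 log units) apart, within the scatter of two such steps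

On these data alone, whether the trend continues to a longer chain such as butyl, or holds for a branched chain such as isopropyl, remains open. Also open, as far as these compounds go, is how propyl behaves with furan-2-yl in place of phenyl on the saturated chain carbon bound to an aromatic carbon.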